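The compounds below may be only part of what the source reports. "The series", "measured", "known", "first", "only" and "open" are said of these compounds alone.

Working notes on the series

For the measured compounds named here, all compounds so far have been run in a functional assay on A-431 cells (Homo sapiens) for cytotoxicity, read by MTT assay, with a stated time of 72 h, tested at 1 uM; on this read-out higher numbers stand for more inhibition of growth at the one concentration tested and lower numbers for less inhibition of growth. Measured so far:

compound 1, `N/C(=N\NC(=S)N1CCCCCC1)c1ccccn1`, gives 18.8%
compound 2, `N/C(=N\NC(=S)N1CCSCC1)c1ccccn1`, gives 31.7%
compound 3, `N/C(=N\NC(=S)N1CCSCC1)c1ccc(F)cn1`, gives 48.7%

Compound 1 gives the lowest of the three numbers; compound 2 and compound 3 both lie above it by more than the usual scatter. How the core of compound 1 differs from the core of compound 2 is not broken down here.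

One single-point change is documented within the measured set: from compound 2 to compound 3 the change is fluoro in place of hydrogen on an aromatic carbon, and it gives a number 17 percentage points higher from compound 2 to compound 3 (beyond the scatter).

Compound 4, `N/C(=N\NC(=S)N1CCCCCC1)c1ccc(F)cn1`, has not yet been measured. It carries the same change relative to compound 1, namely (fluoro in place of hydrogen on an aromatic carbon); the place lines of the two changes agree word for word, so this is the same change applied to the core of compound 1 instead of the core of compound 2.

For compound 4 a step of about a number 15.2 percentage points higher from compound 1 to compound 4 (beyond the scatter) is expected, set beside a number 17 percentage points higher from compound 2 to compound 3 (beyond the scatter). This rests on that one precedent only; since the two cores differ in a way not broken down here, the transfer is not assured, and the range is kept wide. Compound 4 is therefore estimated at 34%, with a likely range from 20% to 50%.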

Compound 4, percent growth inhibition at one concentration: 50.3%
Compound 4: middle estimate off by 16.3 percentage points, on the low side; measured number outside the range, above it.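

In this assay, fluoro in place of hydrogen on an aromatic carbon gives a number 31.5 percentage points higher from compound 1 to compound 4 (beyond the scatter), so the direction seen on the core of compound 2 also holds on the core of compound 1. The size of the step does not carry over, and the change cannot be treated as a fixed increment across these two cores: the same change on two cores in this assay, a number 17 percentage points higher (beyond the scatter) from compound 2 to compound 3 and a number 31.5 percentage points higher (beyond the scatter) from compound 1 to compound 4, 14.5 percentage points apart, beyond the scatter of two such steps. These results rest on one pair for each core at a single concentration, so they do not show how the change would behave on any further core, and they do not tell which feature of the two cores goes with the larger step.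

The compounds shown leave open whether another group on the same aromatic carbon, such as chloro, methyl, methoxy or nitrile, would follow fluoro in giving a higher number on both cores and in giving steps of unequal size. They also leave open whether an amine or a carboxylic acid at that place would keep the direction seen with fluoro.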